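The source may report more compounds than this note shows. Statements on the series, on what has been measured and on what is new or still open speak of the compounds shown alone.

Measured so far in a functional assay on Vero cells (Chlorocebus sabaeus) for cytotoxicity; a higher number here means a weaker inhibitor, a lower number a stronger inhibitor:

Compound 1 `Nc1ncnc2c1ncn2[C@H]1C=C(F)[C@@H](CO)O1`: > 100000 nM
Compound 2 `OC[C@H]1O[C@@H](n2cnc3c(O)ncnc32)C=C1F`: > 100000 nM

Both entries are limits of the assay and not numbers. Compound 1 stands at a limit, > 100000 nM. Compound 2, with hydroxy in place of amino on an aromatic carbon, also stands at a limit, > 100000 nM. Going by the values given here, the only measured change is therefore a step that the two limits leave unreadable from compound 1 to compound 2, and it offers no size to build on. All the data sit in one place: the limit of > 100000 nM in this assay, at which 2 of the 2 values shown sit.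

Compound 3 `Nc1ncnc2c1ncn2[C@@H]1C=C(F)[C@H](CO)O1` has not yet been measured. It differs from compound 1 as follows: the two compounds have the same atoms and bonds and differ only in configuration as drawn: 2 of 2 stereo elements differ (all stereocentres are inverted: mirror images); a stereocentre at a saturated ring carbon is drawn R in compound 1 and S in compound 3; a stereocentre at a saturated ring carbon is drawn R in compound 1 and S in compound 3. Among the compounds with values here, no pair of mirror images has been measured here, so the data give no size for such a change. Compound 3 is expected to stay at the same limit in this assay because compound 1 sits at > 100000 nM and no atom or bond changes. The expected change is a number no higher from compound 1 to compound 3 (the limit leaves the size open), with no direction foreseen and none expected beyond the scatter. For compound 3 the estimated value is 100000 nM, with an expected range from 30000 nM to 200000 nM.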

Compound 3, half-maximal inhibitory concentration: > 100000 nM
Compound 3: no number, only a limit (the forecaster's own chance of this, stated with the estimate: 85%); the middle value lies on the limit itself.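

Compound 1 and its mirror image, compound 3, both stand at a limit of this assay and not at a number, so no step between them can be read: the limit of > 100000 nM in this assay, at which 3 of the 3 values shown sit.

The compounds shown leave open whether inverting the configuration, or placing hydroxy in place of amino, changes the read-out at all, as none of them gives a number.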